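Pentyl in place of tert-butyl on a fused triazole core

This account rests on a few compounds, and the source may have more. Where it says the series, first, only, none or still open, it means among the compounds named here.

Compound 1, `Fc1ccc(-c2nnc3nnc(N4CCCC4)n3n2)cc1`: in a functional assay on BeWo cells (Homo sapiens) for cytotoxicity, read by MTT assay, with a stated time of 72 h (a lower number here means a stronger inhibitor, a higher number a weaker inhibitor), compound 1 gives > 100000 nM, which is a limit of the assay and not a number.
Compound 2, `CC(C)(C)c1nnc2nnc(N3CCCC3)nn12`: in this assay compound 2 gives 12500 nM.

Among the compounds with values here, compound 2 holds the only numerical value shown here; the result for compound 1 sits at the limit described in the limit of > 100000 nM in this assay, at which 1 of the 2 values shown sits, so no step between the two measured compounds can be sized. Compound 3, `CCCCCc1nnc2nnc(N3CCCC3)nn12`, differs from compound 2 in one place: pentyl in place of tert-butyl on an aromatic carbon. Within the data shown here, no measured pair shows what exchanging one alkyl chain for another does on this core, so the expected step from compound 2 to compound 3 in this assay is set close to none beyond the usual scatter, with a slight lean toward a weaker result: a 1.2-fold higher number from compound 2 to compound 3 (0.08 log units; within the scatter). On that basis compound 3 is estimated at 15000 nM, within a range from 4000 nM to 60000 nM.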

Compound 3, half-maximal inhibitory concentration: 27900 nM
For compound 3 the middle estimate is 1.9-fold (0.27 log units) below the measured one; the measured number falls inside the stated range.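

In this assay, within the data shown here, the exchange of tert-butyl for pentyl on this aromatic carbon gives a 2.2-fold higher number from compound 2 to compound 3 (0.35 log units; beyond the scatter), the first step that can be sized, and it shows that the number responds to which alkyl group sits at this position. The result for compound 1 is a limit of the assay, > 100000 nM, and the steps to it cannot be read. Nothing measured here bears on why pentyl gives the higher number.

The compounds shown leave open what a shorter chain such as ethyl, a ring such as cyclopropyl, or an amine would do at this position. They also leave open whether the step would keep its size with a different group in place of the other substituent on the shared core.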